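A few compounds are considered here, and "the series" means these few. Any claim that something is new, unique, unknown or untested is made for them only; others in the source may bear on it.

Compound 1 `N#Cc1c(-c2ccc(F)cc2)nc2c(c(-c3ccccc3)nn2-c2ccccc2)c1-c1ccc(O)cc1`: 11600 nM
Compound 2 `Cc1ccc(-c2nc3c(c(-c4ccccc4)nn3-c3ccccc3)c(-c3ccc(O)cc3)c2C#N)cc1`: 3300 nM

Going by the values given here, in a functional assay on MV4-11 cells (Homo sapiens) for antiproliferative activity, read by resazurin assay, with a stated time of 72 h (on this read-out lower numbers stand for stronger inhibition and higher numbers for weaker inhibition), compound 2 stands lowest of the two numbers; the only measured step, a 3.5-fold lower number from compound 1 to compound 2 (0.55 log units; beyond the scatter), separates it from compound 1. Compound 3 `N#Cc1c(-c2ccc(Cl)cc2)nc2c(c(-c3ccccc3)nn2-c2ccccc2)c1-c1ccc(O)cc1` differs from compound 2 by chloro in place of methyl on an aromatic carbon. Among the compounds with values here, the step of a 3.5-fold lower number from compound 1 to compound 2 (0.55 log units; beyond the scatter) is the one measurement that bears on this change, since it swaps groups on the same aromatic carbon, and it was modest. Chloro is neither the fluoro of compound 1 nor the methyl of compound 2, so for compound 3 a small rise in this assay is expected, a 1.5-fold higher number from compound 2 to compound 3 (0.18 log units; within the scatter). Compound 3 is therefore estimated at 5000 nM, within 2000 nM to 14000 nM.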

Compound 3, half-maximal inhibitory concentration: 25100 nM
Compound 3: the middle estimate sits 5.0-fold (0.70 log units) below what was measured; the whole stated range lies below it.
By their numbers in this assay, from the lowest: compound 2; then compound 1; then compound 3.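

In this assay the change from 4-methylphenyl to 4-chlorophenyl gives a 7.6-fold higher number from compound 2 to compound 3 (0.88 log units; beyond the scatter) and shows that this aromatic carbon responds strongly to the exchange of one group for another. Chloro and fluoro also differ here, with a 2.2-fold higher number from compound 1 to compound 3 (0.34 log units; beyond the scatter) among the three compounds, so the two halogens do not read alike and methyl holds the lowest number. No measured evidence accounts for this order. The compounds shown leave open how an amine, a methoxy group or a longer chain would read on this carbon.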